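A few compounds are considered here, and "the series" means these few. Any claim that something is new, unique, unknown or untested is made for them only; others in the source may bear on it.

In a functional assay on DU-145 cells (Homo sapiens) for antiproliferative activity, read by sulforhodamine B assay (a higher number here means a weaker inhibitor, a lower number a stronger inhibitor), compound 3 `CCCCCCCCCCCCCCCCCCNC(=O)[C@@H]1CSC(c2ccc(O)cc2)N1` gives 3100 nM, the lowest of the three numbers, though the other two sit within the scatter of it: compound 2 `CCCCCCCCCCCCCCCCCCNC(=O)[C@@H]1CSC(c2cc(OC)c(OC)c(OC)c2)N1` gives 3900 nM and compound 1 `CCCCCCCCCCCCCCCCCCNC(=O)[C@@H]1CSC(c2cccc(O)c2)N1` gives 5700 nM. The steps of a 1.3-fold lower number from compound 2 to compound 3 (0.10 log units; within the scatter) and a 1.8-fold lower number from compound 1 to compound 3 (0.26 log units; within the scatter) both stay within the scatter, as does a 1.5-fold lower number from compound 1 to compound 2 (0.16 log units; within the scatter). Compound 4 `CCCCCCCCCCCCCCCCCCNC(=O)[C@@H]1CSC(c2ccc(OCC)cc2)N1` differs from compound 3 by ethyl in place of hydrogen on an oxygen on an aromatic ring. Going by the values given here, no measured step caps a hydroxy group in this way; the nearest comparison is a 1.3-fold lower number from compound 2 to compound 3 (0.10 log units; within the scatter), where an aryl carrying methoxy groups and one carrying a hydroxy group gave no step beyond the scatter. For compound 4 the step of a 1.0-fold higher number from compound 3 to compound 4 (0.01 log units; within the scatter) is therefore expected to stay within the scatter. Compound 4 is estimated at 3200 nM, with a range from 1200 nM to 8500 nM.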

Compound 4, half-maximal inhibitory concentration: > 20000 nM
Compound 4 was reported as a limit; the forecaster's own chance of this, stated with the estimate: 5%; middle value at least 6.2-fold (0.79 log units) from the limit.
By their numbers in this assay, from the lowest: compounds 3, 2 and 1 (each within the scatter of the next). At a limit, above all of these: compound 4.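

Compound 4 is reported only as a limit: the limit of > 20000 nM in this assay, at which 1 of the 4 values shown sits. Going by these compounds alone, putting ethyl on the oxygen of the 4-hydroxyphenyl gives an at least 6.4-fold higher number from compound 3 to compound 4 (0.80 log units; beyond the scatter), the first step beyond the scatter. The 4-ethoxyphenyl also stands apart from the other two aryl groups, with an at least 5.1-fold higher number from compound 2 to compound 4 (0.70 log units; beyond the scatter) and an at least 3.5-fold higher number from compound 1 to compound 4 (0.54 log units; beyond the scatter), yet the methoxy groups of compound 2 go against any rule that capping an oxygen alone raises the number.

As far as these compounds go, the true size of these steps stays open, since each rests on a limit. Also open, from the compounds shown here alone, is whether a propyl chain on this oxygen, or an amine in place of the hydroxy group, behaves like ethyl.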